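The source may report more compounds than this note shows. Statements on the series, on what has been measured and on what is new or still open speak of the compounds shown alone.

Measured in a functional assay on PC-3 cells (Homo sapiens) for inhibition, read by sulforhodamine B assay, with a stated time of 48 h; a higher number here means a weaker inhibitor of growth, a lower number a stronger inhibitor of growth:
- compound 1 `COc1cc2cc(Oc3ccc(NC(=O)Nc4cccc(C(F)(F)F)c4)cc3)c(C)nc2cc1OC` gives 5490 nM
- compound 2 `COc1cc2cc(Oc3ccc(NC(=O)Nc4ccc(Cl)c(C(F)(F)F)c4)cc3)c(C)nc2cc1OC` gives 2960 nM

Compound 2 stands at the lower of the two numbers, but a 1.9-fold lower number from compound 1 to compound 2 (0.27 log units; within the scatter) is within the scatter, so the two measured compounds are not separated by this assay. Compound 3 `COc1cc2cc(Oc3ccc(NC(=O)Nc4ccc(Cl)c(Cl)c4)cc3)c(C)nc2cc1OC` is not yet measured. It differs from compound 2 by chloro in place of trifluoromethyl on an aromatic carbon. Among the measured compounds shown here, no measured step concerns a swap of trifluoromethyl for chloro; the only recorded step, which puts a chloro group in place of a hydrogen, is within the scatter and bears on the present change only loosely. For the measured compounds named here, with no comparable step available, the expected step of a 1.4-fold higher number from compound 2 to compound 3 (0.13 log units; within the scatter) is small, in no clear direction beyond the scatter. Compound 3 is therefore estimated at 4000 nM in this assay, with a range of 1500 nM to 11000 nM.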

Compound 3, concentration for total growth inhibition: 5130 nM
For compound 3 the middle estimate is 1.3-fold (0.11 log units) below the measured one; low and high end bracket the measured number.
By their numbers in this assay, from the lowest: compounds 2, 3 and 1 (each within the scatter of the next).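

In this assay, chloro in place of trifluoromethyl on this aromatic carbon, ortho to a chloro group, gives a 1.7-fold higher number from compound 2 to compound 3 (0.24 log units; within the scatter) and so does not separate the single chlorine from the four-heavy-atom group at this position. The wider exchange of 3-(trifluoromethyl)phenyl for 3,4-dichlorophenyl on the amide-type nitrogen gives a 1.1-fold lower number from compound 1 to compound 3 (0.03 log units; within the scatter) and likewise leaves the two aryl groups unseparated, so no substituent effect can be read from the three compounds in this assay. No supporting data bear on why these steps are so small.

From the compounds shown here alone, it remains open whether another group on this carbon, such as a nitrile, a methoxy group or an amine, would give a step beyond the scatter. Also open, going by these compounds, is whether the same exchange would read alike without the neighbouring chloro group.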